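The compounds below may be only part of what the source reports. "The series", "measured", "known", "first", "only" and "open" are said of these compounds alone.

Compound 1 `CC[C@H](C)[C@H](N)CN(C(=O)[C@@H]1C[C@H]1c1cccc(Cl)c1)c1ccc(-c2ccccc2)cc1`, 2200 nM; compound 2 `CC[C@H](C)[C@H](N)CN(C(=O)[C@@H]1C[C@H]1c1cccs1)c1ccc(-c2ccccc2)cc1`, 360 nM; compound 3 `CC(C)C[C@H](N)CN(C(=O)[C@@H]1C[C@H]1c1ccccc1)c1ccc(-c2ccncc2)cc1`, 13000 nM.

In a functional assay for agonist activity at G protein-coupled receptor 88 (Homo sapiens), read by HTRF and cAMP accumulation (a higher number here means that more compound is needed for the effect, a lower number that less compound is needed), compound 3 stands highest of the three numbers; compound 1 is nearer to it and compound 2 is furthest. Compound 4 `CC(C)C[C@H](N)CN(C(=O)[C@@H]1C[C@H]1c1ccccc1)c1ccc(-c2ccc(Cl)cc2)cc1` differs from compound 3 in one place: 4-chlorophenyl in place of pyridin-4-yl on an aromatic carbon. Within the data shown here, the only measured step, a 6.1-fold lower number from compound 1 to compound 2 (0.79 log units; beyond the scatter), concerns a change on a saturated ring carbon elsewhere in the shared core and so gives no direct guide to this exchange. Among the measured compounds shown here, no measured pair varies the group at this position, so the expectation rests on little. A modest lowering, a 3.3-fold lower number from compound 3 to compound 4 (0.51 log units; beyond the scatter), is expected, though a step within the scatter cannot be excluded. For compound 4 the estimated value in this assay is 4000 nM, with a range from 1000 nM to 15000 nM.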

Compound 4, half-maximal effective concentration: 640 nM
The estimate for compound 4 lay 6.3-fold (0.80 log units) above the measured number; measured number below the stated range.
By their numbers in this assay, from the lowest: compounds 2 and 4 (each within the scatter of the next); then compound 1; then compound 3.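

At this position, on an aromatic carbon of the shared core, the group has a large effect in this assay: the exchange of pyridin-4-yl for 4-chlorophenyl gives a 20-fold lower number from compound 3 to compound 4 (1.31 log units; beyond the scatter), the first step seen here. The exchange removes the ring nitrogen and adds chlorine in a single change, and nothing measured explains the step. The compounds shown leave open which of these two differences carries the step. They also leave open how a 4-methoxyphenyl or 4-fluorophenyl group would compare here.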